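This account rests on a few compounds, and the source may have more. Where it says the series, first, only, none or still open, it means among the compounds named here.

Among the measured compounds shown here, compound 3 `CCCNC(=O)c1cc(Oc2ccc(NC(=O)c3cc4cccnc4n(-c4ccccc4)c3=O)cc2)ccn1` gives 98 nM in a functional assay on HT-29 cells (Homo sapiens) for antiproliferative activity, read by MTT assay, with a stated time of 72 h (a higher number here means a weaker inhibitor, a lower number a stronger inhibitor), the lowest of the three numbers so far; compound 1 `CNC(=O)c1cc(Oc2ccc(NC(=O)c3cc4cccnc4n(-c4ccccc4F)c3=O)cc2)ccn1` gives 260 nM and compound 2 `CCNC(=O)c1cc(Oc2ccc(NC(=O)c3cc4cccnc4n(-c4ccccc4F)c3=O)cc2)ccn1` gives 260 nM, both beyond the scatter from compound 3. Compound 4 `CCCNC(=O)c1cc(Oc2ccc(NC(=O)c3cc4cccnc4n(-c4ccccc4F)c3=O)cc2)ccn1` carries fluoro in place of hydrogen on an aromatic carbon. For the measured compounds named here, no measured step isolates this change: no change at the digits printed from compound 1 to compound 2 (within the scatter) concerns only the chain on the amide nitrogen, and compound 1 and compound 3 differ in both the chain and this fluoro, so the gap between their values cannot be assigned to either change alone. The step of a 1.3-fold higher number from compound 3 to compound 4 (0.12 log units; within the scatter) is therefore expected to be small, if anything toward a slightly higher number. Compound 4 is estimated at 130 nM, within 50 nM to 350 nM.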

Compound 4, half-maximal inhibitory concentration: 200 nM
Compound 4: middle estimate off by 1.5-fold (0.19 log units), on the low side; the range from low to high includes it.
By their numbers in this assay, from the lowest: compound 3; then compounds 4, 1 and 2 (each within the scatter of the next).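

In this assay the fluoro in place of hydrogen, ortho to a large group, now has a reading of its own with the chain held constant: a 2.0-fold higher number from compound 3 to compound 4 (0.31 log units; beyond the scatter) is a modest step. With the fluoro kept, a 1.3-fold lower number from compound 1 to compound 4 (0.11 log units; within the scatter) and a 1.3-fold lower number from compound 2 to compound 4 (0.11 log units; within the scatter) both stay within the scatter, so the chain on the amide nitrogen separates none of the three fluoro compounds. Nothing at hand bears on the origin of the fluoro step. Open, from the compounds shown here alone, is whether a chloro or methoxy group at that place, or a longer chain or an amine on the amide nitrogen, would shift the number.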